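The compounds below may be only part of what the source reports. "The series", "measured", "known", "first", "only" and "open" are said of these compounds alone.

Three compounds of the series share one core and differ only in the group on the amide-type nitrogen. Compound 1 `N[C@H]1CC[C@H](Nc2c(C(=O)NCc3ccco3)nc(Br)c3cccnc23)CC1` carries (furan-2-yl)methyl there; in a functional assay on MDA-MB-435 cells (Homo sapiens) for cytotoxicity, read by MTT assay, with a stated time of 72 h (a lower number here means a stronger inhibitor, a higher number a weaker inhibitor), compound 1 gives only a limit, > 10000 nM, which is the limit of > 10000 nM in this assay, at which 1 of the 3 values shown sits. Compound 2 `N[C@H]1CC[C@H](Nc2c(C(=O)NCc3cccs3)nc(Br)c3cccnc23)CC1` carries (thiophen-2-yl)methyl and in this assay compound 2 gives 4100 nM. Compound 3 `N[C@H]1CC[C@H](Nc2c(C(=O)Nc3ccccc3)nc(Br)c3cccnc23)CC1` carries phenyl and in this assay compound 3 gives 1000 nM, the lowest of the two numbers obtained. The measured steps are an at least 2.4-fold lower number from compound 1 to compound 2 (0.38 log units; beyond the scatter), an at least 10-fold lower number from compound 1 to compound 3 (1.00 log units; beyond the scatter) and a 4.1-fold lower number from compound 2 to compound 3 (0.61 log units; beyond the scatter).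

Compound 4 `C[C@H](NC(=O)c1nc(Br)c2cccnc2c1N[C@H]1CC[C@H](N)CC1)c1ccc(F)cc1` differs from compound 3 by 1-(4-fluorophenyl)ethyl in place of phenyl on an amide-type nitrogen. Among the measured compounds shown here, the only step that bears on it is a 4.1-fold lower number from compound 2 to compound 3 (0.61 log units; beyond the scatter), where a ring bound directly to the amide-type nitrogen gave the lower number than a ring set on a saturated chain carbon bound to that nitrogen; compound 4 returns to a saturated carbon, now bearing a methyl and a fluorine-substituted ring, for which no measured pair exists. A step of a 2.2-fold higher number from compound 3 to compound 4 (0.34 log units; beyond the scatter) toward a higher number is therefore expected. Compound 4 is estimated at 2200 nM in this assay, within 600 nM to 8000 nM.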

Compound 4, half-maximal inhibitory concentration: > 10000 nM
Compound 4 was reported as a limit; the forecaster's own chance of this, stated with the estimate: 10%; at least 4.5-fold (0.65 log units) between middle value and limit.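

On the amide-type nitrogen, replacing phenyl with 1-(4-fluorophenyl)ethyl raises the number sharply in this assay, with an at least 10-fold higher number from compound 3 to compound 4 (1.00 log units; beyond the scatter), and the same group also stands behind (thiophen-2-yl)methyl, with an at least 2.4-fold higher number from compound 2 to compound 4 (0.38 log units; beyond the scatter). Compound 4 gives only a limit, the same one as compound 1, so the step between those two cannot be read: the limit of > 10000 nM in this assay, at which 2 of the 4 values shown sit. Compound 2 also has its ring on a saturated chain carbon yet gives a measured number, so that carbon alone does not separate the compounds at the limit from those below it.

From the compounds shown here alone, compound 4 brings the methyl, the fluorine and the defined stereocentre together, so the share of each in the step stays open. Benzyl and 4-fluorophenyl on the same nitrogen would be the groups that could separate them.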